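The source may report more compounds than this note shows. Statements on the series, on what has been measured and on what is new or still open speak of the compounds shown alone.

Measured compounds:
Compound 1, `COc1nc(-c2nc3ccccc3n2C)cc(-c2ccccc2)c1C#N`, in a functional assay on aorta (Rattus norvegicus, strain Wister) (a higher number here means a weaker inhibitor, a lower number a stronger inhibitor), gives 300000 nM.
Compound 2, `CCOc1nc(-c2nc3ccccc3n2C)cc(-c2ccccc2)c1C#N`, in this assay gives 364000 nM.

Only these two numbers are known, and they lie within the scatter of each other: the step of a 1.2-fold higher number from compound 1 to compound 2 (0.08 log units; within the scatter) counts as no change. Compound 1 therefore stands beside compound 2 rather than apart from it, and both are weak inhibitors in this assay.

Compound 3 is `COc1nc(-c2nc3ccccc3n2C)cc(-c2ccc(C)cc2)c1C#N`. It differs from compound 1 in one place: methyl in place of hydrogen on an aromatic carbon. Put another way, the phenyl group on the shared core becomes a 4-methylphenyl group, the new methyl sitting para to a large group on that six-membered ring of carbon only.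

Among the measured compounds shown here, no measured step touches this ring. For the measured compounds named here, the only step known, from compound 1 to compound 2, adds a methyl at a different place, on a saturated chain carbon bound to an oxygen on the aromatic ring, and it stayed within the scatter. On that basis compound 3 is expected to move little, with an estimated step of no change at the digits printed from compound 1 to compound 3 (within the scatter), in no firm direction. The estimate for compound 3 in this assay is 300000 nM, with a range from 100000 nM to 900000 nM.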

Compound 3, half-maximal inhibitory concentration: 295000 nM
The estimate for compound 3 lay 1.0-fold (0.01 log units) above the measured number; low and high end bracket the measured number.
By their numbers in this assay, from the lowest: compounds 3, 1 and 2 (each within the scatter of the next).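

Adding a methyl on an aromatic carbon, para to a large group, turns phenyl into 4-methylphenyl and gives a 1.0-fold lower number from compound 1 to compound 3 (0.01 log units; within the scatter) in this assay. Among the compounds shown here, this is the first look at this ring, and it shows that one added methyl at this place leaves the reading within the scatter, so compound 3 remains as weak an inhibitor as compound 1. The added methyl on the chain in compound 2 likewise stayed within the scatter, so neither of the two places probed so far has yet shown a step that can be told from noise, and no measurement at hand explains this result.

A single methyl is a small probe, so this result says little about what a chlorine atom, a methoxy group, an amine or a carboxylic acid would do at the same place on the ring. Also open, going by these compounds, is whether any change to this ring can bring the number in this assay clearly away from where these three compounds sit, and whether a methyl elsewhere on the ring would behave as this one does.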